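The source may report more compounds than this note shows. Statements on the series, on what has been measured and on what is new or still open speak of the compounds shown alone.

Measured compounds:
compound 1, `COc1ccc(-c2[nH]c3cc(OC)cc(OC)c3c(=O)c2I)cc1`: > 86200 nM
compound 2, `COc1ccc(-c2cc(=O)c3c(OC)cc(OC)cc3n2S(=O)(=O)c2ccc(C)c([N+](=O)[O-])c2)cc1`: > 51700 nM

Both figures come from a functional assay on SUP-B15 cells (Homo sapiens) for antiproliferative activity, with a stated time of 72 h; a lower number here means that less compound is needed, a higher number that more compound is needed for the effect. For compound 2 the figure > 51700 nM is a limit of the assay, not a measured number. For compound 1 the figure > 86200 nM is likewise a limit. So compound 2 stands at a limit (the limit of > 51700 nM in this assay, at which 1 of the 2 values shown sits), and the one other value shown also sits at a limit (the limit of > 86200 nM in this assay, at which 1 of the 2 values shown sits), leaving no number to compare between the two. Compound 3, `COc1ccc(-c2cc(=O)c3c(OC)cc(OC)cc3n2S(=O)(=O)c2c(F)c(F)c(F)c(F)c2F)cc1`, keeps everything of compound 2 except one group: 2,3,4,5,6-pentafluorophenyl in place of 4-methyl-3-nitrophenyl on a sulfonyl sulfur. Among the compounds with values here, no step between two measured compounds is available, so there is no ground for expecting a change in this assay beyond the usual scatter, and compound 3 is expected to stay at or near a limit as well. The estimate for compound 3 is 60000 nM, within 15000 nM to 250000 nM. The step this estimate implies is expected to be a step that the limit leaves unreadable from compound 2 to compound 3.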

Compound 3, half-maximal effective concentration: 4100 nM
Beside the measured number, compound 3's estimate is 15-fold (1.17 log units) above it, and the stated range ends above it.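

Within the data shown here, compound 3 gives the first real number in this assay, which shows that the group on the sulfonyl sulfur can decide whether this series registers any effect on these cells. Placing 2,3,4,5,6-pentafluorophenyl in place of 4-methyl-3-nitrophenyl at that position gives an at least 12-fold lower number from compound 2 to compound 3 (1.10 log units; beyond the scatter). That step is a minimum rather than an exact size because compound 2 stands at a limit of the assay, not at a measured number: the limit of > 51700 nM in this assay, at which 1 of the 3 values shown sits.

With only these two groups compared, the step cannot be assigned to the added fluorines or to the loss of the nitro or methyl group. From the compounds shown here alone, what an unsubstituted phenyl, a phenyl carrying a single fluorine, or a simple methyl on the sulfonyl sulfur would give remains open.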